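Replacing pyrimidin-2-yl on the sulfur of compound 1

The source may report more compounds than this note shows. Statements on the series, on what has been measured and on what is new or still open speak of the compounds shown alone.

Of the compounds shown here, two have numbers so far. In a physicochemical assay for lipophilicity (a lower number here means a more polar compound, a higher number a more lipophilic compound), compound 1 `CCCCCCCN(CCCCCSc1ncccn1)C(=O)Nc1ccc(F)cc1F` gives 5.41 and holds the lower of the two numbers. Compound 2 `CCCCCCCN(CCCCCSc1nc(O)cc(Cc2ccccc2)n1)C(=O)NC(C)C` gives 7.4 and stands higher by a gap beyond the scatter.

The next compound to be measured is compound 3 `CCCCCCCN(CCCCCSc1n[nH]c(-c2ccccc2)n1)C(=O)Nc1ccc(F)cc1F` which differs from compound 1 in one place: 5-phenyl-1H-1,2,4-triazol-3-yl in place of pyrimidin-2-yl on a sulfur. In words, 5-phenyl-1H-1,2,4-triazol-3-yl stands in place of pyrimidin-2-yl on a sulfur. The entering group carries a six-membered aromatic ring of carbon only in addition to its five-membered aromatic ring.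

Among the measured compounds shown here, no step between closely matched compounds has been measured, so the size of this change rests on judgement. A rise is expected, with the estimated step of a number 1.09 log units higher from compound 1 to compound 3 (beyond the scatter) lying beyond the scatter. Compound 2 at 7.4 shows how high the series can reach, and the expectation for the new compound stays under that number. In this assay compound 3 is expected at 6.5 with an estimated range from 5.8 to 7.2 around that middle.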

Compound 3, partition coefficient: 6.78
For compound 3 the middle estimate is 0.28 log units below the measured one, within the range that was stated.
By their numbers in this assay, from the lowest: compound 1; then compound 3; then compound 2.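

In this assay, among the compounds shown here, 5-phenyl-1H-1,2,4-triazol-3-yl in place of pyrimidin-2-yl on a sulfur gives a number 1.37 log units higher from compound 1 to compound 3 (beyond the scatter), the only step so far that can be read at one place, and it shows that this position can move the number by a large step while the rest of compound 1 stays fixed. The exchange alters several things together: the group grows from 6 to 11 heavy atoms, the entering group adds a six-membered aromatic ring of carbon only, a five-membered aromatic ring replaces the six-membered one on the sulfur, and a hydrogen-bond donor appears, so this single pair cannot divide the step among them. No measurement at hand bears on the reason for the rise.

Still open, going by these compounds, is how the step divides between the five-membered ring and the phenyl, which 1H-1,2,4-triazol-3-yl without the phenyl, or pyrimidin-2-yl carrying a phenyl, on the same sulfur would separate. For the compounds shown here, also open is how far this position can move the number the other way, for example with a group carrying an amine or a carboxylic acid, as the one step in hand runs upward.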